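The source may hold more compounds than are shown below. What is called first, only, known or untested is meant among the compounds shown, and "the series" means these compounds.

- Compound 1 `COc1cc(Nc2ncnc3c(NC(=O)Nc4ccc(F)cc4C(F)(F)F)cccc23)cc(OC)c1`: 2970 nM
- Compound 2 `COc1cc(Nc2ncnc3c(NC(=O)Nc4ccc(Cl)cc4)cccc23)cc(OC)c1`: 2490 nM

Among the compounds with values here, in a functional assay on RT-112 cells (Homo sapiens) for antiproliferative activity, read by MTT assay, with a stated time of 72 h (a lower number here means a stronger inhibitor of growth, a higher number a weaker inhibitor of growth), compound 2 stands within the scatter of compound 1, the only other compound measured. Compound 3 `COc1cc(Nc2ncnc3c(NC(=O)Nc4ccc(Cl)cc4Cl)cccc23)cc(OC)c1` differs from compound 2 by one change, chloro in place of hydrogen on an aromatic carbon. Within the data shown here, the one measured step bearing on this, a 1.2-fold lower number from compound 1 to compound 2 (0.08 log units; within the scatter), exchanges 4-fluoro-2-(trifluoromethyl)phenyl for 4-chlorophenyl and stays within the scatter. No step beyond the scatter is therefore expected in this assay. The expected change is a 1.0-fold lower number from compound 2 to compound 3 (0.02 log units; within the scatter). For compound 3 the estimate is 2400 nM, with an expected range of 1000 nM to 5500 nM.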

Compound 3, concentration for 50% growth inhibition: 3060 nM
For compound 3 the middle estimate is 1.3-fold (0.11 log units) below the measured one, within the range that was stated.
By their numbers in this assay, from the lowest: compounds 2, 1 and 3 (each within the scatter of the next).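

Chloro in place of hydrogen on an aromatic carbon, ortho to a large group, turns 4-chlorophenyl into 2,4-dichlorophenyl and in this assay gives a 1.2-fold higher number from compound 2 to compound 3 (0.09 log units; within the scatter) and so no readable shift at this position. Exchanging 4-fluoro-2-(trifluoromethyl)phenyl for 2,4-dichlorophenyl gives a 1.0-fold higher number from compound 1 to compound 3 (0.01 log units; within the scatter) and also stays within the scatter. Nothing available bears on why these numbers stay level. The compounds shown leave open whether an amine or a carboxylic acid at this position would move the number beyond the scatter.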